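Pentyl in Place of Isopropyl: a Chain Extension Weighed

The compounds below may be only part of what the source reports. "The series", "measured", "known", "first", "only" and "open" are said of these compounds alone.

Three compounds share one core and differ only in the group on the oxygen next to the carbonyl. Compound 1 `N#C[Se]c1ccc(NC(=O)OCc2ccccc2)cc1` gives 13300 nM in a functional assay on HT-29 cells (Homo sapiens) for cytotoxicity, read by MTT assay, with a stated time of 72 h; a lower number here means a stronger inhibitor of growth, a higher number a weaker inhibitor of growth. Compound 2 `N#C[Se]c1ccc(NC(=O)Oc2ccccc2)cc1` gives 11700 nM in this assay, and compound 3 `CC(C)COC(=O)Nc1ccc([Se]C#N)cc1` gives 8100 nM. Compound 3 thus carries the lowest of the three numbers, yet its distance from compound 2 and from compound 1 lies within the scatter, so the three cannot be ranked. Both steps that lead to compound 3 bear on the present question: a 1.6-fold lower number from compound 1 to compound 3 (0.22 log units; within the scatter) and a 1.4-fold lower number from compound 2 to compound 3 (0.16 log units; within the scatter), each within the scatter.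

Compound 4 `CCCCCCOC(=O)Nc1ccc([Se]C#N)cc1` has not yet been measured. Relative to compound 3 the change is pentyl in place of isopropyl on a saturated chain carbon bound to an oxygen next to a carbonyl group. Replacing phenyl with isopropyl or isobutyl at this place moved the number only within the scatter, and a further exchange of isopropyl for pentyl is expected to behave the same way in this assay, with no step beyond the scatter and at most a slightly lower number. On the strength of a 1.6-fold lower number from compound 1 to compound 3 (0.22 log units; within the scatter) and a 1.4-fold lower number from compound 2 to compound 3 (0.16 log units; within the scatter), the expected step is a 1.2-fold lower number from compound 3 to compound 4 (0.10 log units; within the scatter). Compound 4 is therefore estimated to give about 6500 nM in this assay, within a range from 2700 nM to 15000 nM.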

Compound 4, concentration for 50% growth inhibition: 10700 nM
Compound 4: the middle estimate sits 1.6-fold (0.22 log units) below what was measured, within the range that was stated.
By their numbers in this assay, from the lowest: compounds 3, 4, 2 and 1 (each within the scatter of the next).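

In this assay the exchange of isopropyl for pentyl on a saturated chain carbon bound to an oxygen next to a carbonyl group gives a 1.3-fold higher number from compound 3 to compound 4 (0.12 log units; within the scatter) and so adds a second saturated chain to the series, with hexyl on the oxygen where compound 3 carries isobutyl. The comparison with the phenyl-bearing compounds reads the same way, with a 1.1-fold lower number from compound 2 to compound 4 (0.04 log units; within the scatter) and a 1.2-fold lower number from compound 1 to compound 4 (0.09 log units; within the scatter) as its two steps, so neither extending the chain nor replacing phenyl with a chain has produced a step beyond the scatter, and the four compounds cannot be ranked. Nothing at hand accounts for this flat response.

The compounds shown leave open whether any group at this place can carry the number beyond the scatter, for example a longer chain such as dodecyl or a chain ending in an amine or a carboxylic acid. They also leave open whether the same flat response would appear on a cell line other than the one used in this assay and whether it would hold for changes made elsewhere on the shared core.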